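Compound 1 and the methyl on its phenol oxygen

The compounds below may be only part of what the source reports. "The series", "measured", "known", "first", "only" and "open" are said of these compounds alone.

Among the compounds with values here, compound 1 `O=C(Nc1cccc(-n2cc(-c3ccncc3)c(-c3cc(O)cc(Cl)c3)n2)c1)Nc1ccc(Cl)c(Cl)c1` gives in a functional assay on SF-539 cells (Homo sapiens) for inhibition, read by sulforhodamine B assay, with a stated time of 48 h, tested at 100 uM (a lower number here means a stronger effect, a higher number a weaker effect of the compound at the concentration tested), a value of -52%, the higher of the two numbers known here; compound 2 `COc1cc(Cl)cc(-c2nn(-c3cccc(NC(=O)Nc4cc(C(F)(F)F)cc(C(F)(F)F)c4)c3)cc2-c2ccncc2)c1` gives -73% in this assay, a gap beyond the scatter. Compound 3 `COc1cc(Cl)cc(-c2nn(-c3cccc(NC(=O)Nc4ccc(Cl)c(Cl)c4)c3)cc2-c2ccncc2)c1` has not been measured. It differs from compound 1 by methyl in place of hydrogen on an oxygen on an aromatic ring, hydroxy to methoxy. Within the data shown here, compound 2 also carries the methoxy, but differs from compound 3 elsewhere as well, so no single-point step is known. A modest shift toward a stronger effect in this assay is expected for compound 3, as the step of a number 8 percentage points lower from compound 1 to compound 3 (within the scatter), probably within the scatter. Compound 3 is estimated at -60%, between -88% and -32%.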

Compound 3, a percentage reported as activity, at one concentration (the size of the read-out at that concentration, not a potency): -40%
The estimate for compound 3 lay 20 percentage points below the measured number; low and high end bracket the measured number.
By their numbers in this assay, from the lowest: compound 2; then compound 1; then compound 3.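

With the methyl on the oxygen on the aromatic ring as the only difference, hydroxy to methoxy in this assay gives a number 12 percentage points higher from compound 1 to compound 3 (beyond the scatter) and so weakens the effect at this position by a modest step. The free hydroxy therefore gives the stronger effect of this pair, which the earlier values alone could not show. Nothing at hand bears on why the step runs this way. From the compounds shown here alone, what an amine or a longer chain such as ethoxy would give in place of the hydroxy stays open, as does whether the step holds with other groups on the urea.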